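This account rests on a few compounds, and the source may have more. Where it says the series, first, only, none or still open, it means among the compounds named here.

In a functional assay on HeLa cells (Homo sapiens) for antiproliferative activity, read by MTT assay, with a stated time of 72 h (on this read-out higher numbers stand for weaker inhibition and lower numbers for stronger inhibition), compound 1 (`C=CC(=O)Nc1cccc(Oc2nc(Nc3ccn(C)n3)nc3c2CSCC3)c1`), with vinyl on the carbonyl carbon, gives 25800 nM as a measured number. Compound 2 (`C/C=C/C(=O)Nc1cccc(Oc2nc(Nc3ccn(C)n3)nc3c2CSCC3)c1`) gives > 50000 nM in this assay and this is a limit of the assay, not a number.

Compound 3 (`CC/C=C/C(=O)Nc1cccc(Oc2nc(Nc3ccn(C)n3)nc3c2CSCC3)c1`) differs from compound 2 in one place: methyl in place of hydrogen on a saturated chain carbon bound to a double-bonded chain carbon, so that prop-1-en-1-yl becomes but-1-en-1-yl.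

Going by the values given here, only one measured step bears on this change: an at least 1.9-fold higher number from compound 1 to compound 2 (0.28 log units; that floor lies within the scatter), which came from prop-1-en-1-yl in place of vinyl on a carbonyl carbon. Among the compounds with values here, its true size is unknown, and the series holds no measured step for a further carbon on this chain. No step beyond the scatter is therefore expected in this assay, and neither direction is favoured. The estimated change is a number no higher from compound 2 to compound 3 (the limit leaves the size open), and another reading reported only as a limit is the likeliest outcome. For compound 3 the expected value is 50000 nM, with an estimated range from 20000 nM to 100000 nM in this assay.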

Compound 3, half-maximal inhibitory concentration: > 50000 nM
Compound 3 ended at the assay's limit; the forecaster's own chance of this, stated with the estimate: 65%; the middle value sits exactly at the limit.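

The step between compound 2 and compound 3 cannot be read in this assay, because both readings sit at the same ceiling: the limit of > 50000 nM in this assay, at which 2 of the 3 values shown sit.

The extra methyl on the saturated chain carbon therefore adds no measurable information beyond showing that but-1-en-1-yl, like prop-1-en-1-yl, does not give a measured number here. Against the vinyl of compound 1, but-1-en-1-yl gives an at least 1.9-fold higher number from compound 1 to compound 3 (0.28 log units; that floor lies within the scatter), so even this second chain extension does not establish a real change from compound 1. Among these three compounds, only the vinyl compound gives a measured number, while both longer alkenyl groups end at the limit, and this observation goes no further than compound 1, compound 2 and compound 3.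

Going by these compounds, the true sizes of the steps from compound 1 remain unknown, and so does any ordering of compound 2 and compound 3. Also open, on these data alone, is whether a but-1-en-1-yl chain carrying an amine, or a saturated ethyl on the carbonyl carbon, would give a measured number in this assay.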